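Chain length step from compound 2 to compound 3

The compounds below may be only part of what the source reports. "The series", "measured", "known", "first", "only" and "open" are said of these compounds alone.

Compound 1 `CNC(=O)[C@@H](CO)NCc1ccc(OCc2cccc(F)c2)cc1` gives 6600 nM in an assay on isolated protein for binding affinity to Sigma non-opioid intracellular receptor 1 (Rattus norvegicus); on this read-out lower numbers stand for stronger inhibition and higher numbers for weaker inhibition. Compound 2 `C[C@H](NCc1ccc(OCCCCc2ccccc2)cc1)C(N)=O` gives 550 nM in this assay and holds the lower of the two numbers; the gap to compound 1 lies beyond the usual scatter. The two compounds differ at more than one place, so their gap cannot be tied to a single change. Compound 3 `C[C@H](NCc1ccc(OCCCCCc2ccccc2)cc1)C(N)=O` differs from compound 2 in one place: benzyl in place of phenyl on a saturated chain carbon, four bonds along the chain from an oxygen on an aromatic ring. Within the data shown here, no pair of measured compounds shows this change, so no measured step can be drawn on. A change of this size at the far end of the chain is expected to shift the number in this assay only a little, in either direction, not clearly beyond the scatter. The step this estimate means is expected to be a 1.4-fold lower number from compound 2 to compound 3 (0.14 log units; within the scatter). Compound 3 is estimated at 400 nM in this assay, with a range from 150 nM to 1100 nM.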

Compound 3, half-maximal inhibitory concentration: > 10000 nM
Compound 3 gave a limit, no number (the forecaster's own chance of this, stated with the estimate: 5%); middle value at least 25-fold (1.39 log units) away from the limit.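

In this assay, the place on a saturated chain carbon, four bonds along the chain from an oxygen on an aromatic ring, proves sensitive: benzyl in place of phenyl gives an at least 18-fold higher number from compound 2 to compound 3 (1.25 log units; beyond the scatter). Among these compounds, this is the first change that can be tied to a single place, since compound 1 and compound 2 differ at more than one, and it shows that a change this small at the far end of the chain can move the read-out well beyond the scatter. Compound 3 stands as a limit and not a number, so the step can be read only from one side: the limit of > 10000 nM in this assay, at which 1 of the 3 values shown sits.

From the compounds shown here alone, what a longer chain, a shorter chain or an amine in place of benzyl would do at this place stays open. One pair also leaves open whether the same change would act alike on the core of compound 1.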